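The compounds below may be only part of what the source reports. "The series", "measured", "known", "first", "only" and "open" are said of these compounds alone.

Among the compounds with values here, in a functional assay on MCF7 cells (Homo sapiens) for cytotoxicity, read by MTT assay, with a stated time of 72 h (on this read-out higher numbers stand for weaker inhibition and lower numbers for stronger inhibition), compound 1 `CNC(=O)c1cc(Oc2ccc(C3=NNC(c4ccc(Cl)cc4Cl)C3)cc2)ccn1` shows "not determined" (no result reported) and compound 2 `CNC(=O)c1cc(Oc2ccc(C3=NNC(c4cc(OC)c(OC)c(OC)c4)C3)cc2)ccn1` shows "not determined" (no result reported), so compound 3 `CNC(=O)c1cc(Oc2ccc(C3=NNC(c4cccc([N+](=O)[O-])c4)C3)cc2)ccn1`, at 35400 nM, holds the only number and can be ranked against nothing. Compound 4 `CNC(=O)c1cc(Oc2ccc(C3=NNC(c4ccc(F)cc4)C3)cc2)ccn1` carries one change on the shared core: 4-fluorophenyl in place of 3-nitrophenyl on a saturated ring carbon. Within the data shown here, no measured step exists to size this swap, so the expectation rests on compound 3 at 35400 nM alone. The estimated step is a 1.2-fold lower number from compound 3 to compound 4 (0.07 log units; within the scatter), and none beyond the scatter is expected in this assay. For compound 4 the expected value is 30000 nM, within an estimated range of 10000 nM to 80000 nM.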

Compound 4, half-maximal inhibitory concentration: 9480 nM
Beside the measured number, compound 4's estimate is 3.2-fold (0.50 log units) above it; measured number outside the range, below it.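

In this assay, within the data shown here, the group on this saturated ring carbon affects the read-out: 4-fluorophenyl in place of 3-nitrophenyl gives a 3.7-fold lower number from compound 3 to compound 4 (0.57 log units; beyond the scatter), a modest step beyond the scatter and the first sized change at this position. The swap alters both the substituent and its place on the phenyl ring, so the step cannot be assigned to either alone. No measured evidence accounts for this step. Still open, going by these compounds, is how this position responds to a phenyl ring carrying an amine, or to a longer chain replacing the ring. The missing results for compound 1 and compound 2 mean that their steps cannot be read.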